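Mirror-image partner of an inactive thiourea

The compounds below may be only part of what the source reports. "The series", "measured", "known", "first", "only" and "open" are said of these compounds alone.

The compounds described here share one core, and they are tested in a functional assay on RBL-2H3 cells (Rattus norvegicus) for inhibition; a lower number here means a stronger inhibitor, a higher number a weaker inhibitor. Compound 1 has the structure `Cc1cccc2sc(N/C(S)=N/[C@H](C)c3cccc4ccccc34)nc12`. In this assay compound 1 gives only a limit, > 100000 nM, and not a number. Compound 2 has the structure `C[C@H](/N=C(\S)Nc1nc2ccccc2s1)c1cccc2ccccc12`. Compound 2 also reaches only the limit of this assay, > 100000 nM, so its inhibitory strength is not pinned down by a number. Where compound 2 stands is therefore described by the limit of > 100000 nM in this assay, at which 2 of the 2 values shown sit, and both values shown in this assay sit at that same limit.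

The compound still to be measured is compound 3, with the structure `C[C@@H](/N=C(\S)Nc1nc2ccccc2s1)c1cccc2ccccc12`. Compared with compound 2, the change is the two compounds have the same atoms and bonds and differ only in configuration as drawn: 1 of 2 stereo elements differ; a stereocentre at a saturated chain carbon is drawn S in compound 2 and R in compound 3. Nothing enters and nothing leaves; only the configuration at one saturated chain carbon is inverted. Among the measured compounds shown here, no measured step between two compounds differing in one place exists here. Given that compound 2 already sits at the limit, compound 3 is expected to stay there as well, with a step from a step that the limit leaves unreadable from compound 2 to compound 3 amounting to nothing beyond the scatter. For compound 3 the estimate in this assay is 150000 nM, within a range from 30000 nM to 1000000 nM.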

Compound 3, half-maximal inhibitory concentration: 18900 nM
The estimate for compound 3 lay 7.9-fold (0.90 log units) above the measured number; the measured number lies below the stated range.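

In this assay, inverting the saturated chain carbon from S in compound 2 to R in compound 3 gives an at least 5.2-fold lower number from compound 2 to compound 3 (0.72 log units; beyond the scatter), and this difference can be assigned to configuration alone because of one fact: the fact that compounds 2 and 3 differ only in the configuration as drawn. The methyl group matters as well, since hydrogen in place of methyl on an aromatic carbon goes with an at least 5.2-fold lower number from compound 1 to compound 3 (0.72 log units; beyond the scatter). Compound 3 is the only one of the three with a real number, 18900 nM. Both steps show only a minimum size: each starts from a compound that reached just a limit of the assay.

Going by these compounds, the true size of the gap between compound 2 and compound 3 stays open, as does how far the number would move if the methyl on that aromatic carbon were replaced by a chlorine or a methoxy group instead of hydrogen. Also open, on these data alone, is what a longer chain, such as an ethyl group in place of the methyl on the saturated chain carbon, would do to compound 3.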